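Compound 3 to compound 4: ethoxycarbonyl for iodo

The source may report more compounds than this note shows. Statements on the series, on what has been measured and on what is new or still open speak of the compounds shown alone.

Compound 1 `CCNC(=O)CCc1cccc2c1B(O)OC2`: > 100000 nM (a limit)
Compound 2 `O=C(CCc1cccc2c1B(O)OC2)Nc1nccs1`: > 100000 nM (a limit)
Compound 3 `O=C(CCc1cccc2c1B(O)OC2)Nc1ccc(I)cc1`: 50000 nM (a number)

In a functional assay on HCT-116 cells (Homo sapiens) for antiproliferative activity, read by MTT assay, with a stated time of 72 h (on this read-out lower numbers stand for stronger inhibition and higher numbers for weaker inhibition), only compound 3 reaches a number. Compound 1 and compound 2 rest on the limit of > 100000 nM in this assay, at which 2 of the 3 values shown sit, and give no number. Compound 4 `CCOC(=O)c1ccc(NC(=O)CCc2cccc3c2B(O)OC3)cc1` swaps iodo for ethoxycarbonyl, and ethoxycarbonyl in place of iodo on an aromatic carbon is its whole difference from compound 3. The nearest steps are an at least 2.0-fold lower number from compound 1 to compound 3 (0.30 log units; that floor lies within the scatter) and an at least 2.0-fold lower number from compound 2 to compound 3 (0.30 log units; that floor lies within the scatter) and both bring in 4-iodophenyl, yet neither replaces the iodo. Starting from compound 3 at 50000 nM in this assay no step beyond the scatter is expected. The estimated change is a 1.2-fold higher number from compound 3 to compound 4 (0.08 log units; within the scatter) and it is expected to stay within the scatter. For compound 4 the estimate is 60000 nM with 25000 nM to 100000 nM as its expected range, and a reading at the limit remains possible.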

Compound 4, half-maximal inhibitory concentration: > 100000 nM
Compound 4: a limit, no number; the forecaster's own chance of this, stated with the estimate: 35%; middle value at least 1.6-fold (0.22 log units) away from the limit.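

For the compounds shown here, the earlier steps changed only the group on the amide-type nitrogen, whereas this change is the first on the aromatic carbon, para to a large group. In this assay, ethoxycarbonyl in place of iodo gives an at least 2.0-fold higher number from compound 3 to compound 4 (0.30 log units; that floor lies within the scatter), so this position does not keep a number with this group. The true size of the step stays unknown, and compound 3 remains the only compound with a number: the limit of > 100000 nM in this assay, at which 3 of the 4 values shown sit.

Going by these compounds, whether chloro, an amine or a carboxylic acid on this aromatic carbon would give a number in this assay remains open. So does whether any group there could lower the number of compound 3 beyond the scatter.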